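A few compounds are considered here, and "the series" means these few. Any claim that something is new, unique, unknown or untested is made for them only; others in the source may bear on it.

Three compounds share one core and differ only in the aryl group on a nitrogen of the five-membered aromatic ring with 3 nitrogen. Compound 1 `Cc1cccc(-n2nncc2CN2C(=O)C3(C(C#N)=C(N)Oc4c3c3nc5ccccc5nc3c3ccccc43)c3ccccc32)c1` carries a 3-methylphenyl there and in a functional assay on A549 cells (Homo sapiens) for antiproliferative activity, read by MTT assay, with a stated time of 48 h (on this read-out higher numbers stand for weaker inhibition and lower numbers for stronger inhibition), gives 39600 nM. Compound 2 `N#CC1=C(N)Oc2c(c3nc4ccccc4nc3c3ccccc23)C12C(=O)N(Cc1cnnn1-c1ccc(F)cc1)c1ccccc12` carries a 4-fluorophenyl instead. In this assay compound 2 gives > 50000 nM, which is a limit of the assay and not a number. Compound 3 `N#CC1=C(N)Oc2c(c3nc4ccccc4nc3c3ccccc23)C12C(=O)N(Cc1cnnn1-c1cccc(Br)c1)c1ccccc12` carries a 3-bromophenyl. In this assay compound 3 gives > 50000 nM, which is likewise a limit and not a number. Two of the three values thus sit at the limit of > 50000 nM in this assay, at which 2 of the 3 values shown sit. The step of an at least 1.2-fold higher number from compound 1 to compound 2 (0.10 log units; that floor lies within the scatter) and the step of an at least 1.2-fold higher number from compound 1 to compound 3 (0.10 log units; that floor lies within the scatter) are therefore only floors, and the step that the two limits leave unreadable from compound 2 to compound 3 cannot be read. Compound 4 `CC(=O)Nc1ccc(-n2nncc2CN2C(=O)C3(C(C#N)=C(N)Oc4c3c3nc5ccccc5nc3c3ccccc43)c3ccccc32)cc1` makes the change (4-acetamidophenyl in place of 3-bromophenyl on an aromatic nitrogen). For the measured compounds named here, no measured step tells how a 4-acetamidophenyl behaves against a 3-bromophenyl or a 4-fluorophenyl, and the one compound with a number, compound 1, gives a weak value. The step of an at least 1.1-fold lower number from compound 3 to compound 4 (0.04 log units; that floor lies within the scatter) is therefore expected to be small. Compound 4 is estimated at 45000 nM in this assay, with a range from 15000 nM to 100000 nM.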

Compound 4, half-maximal inhibitory concentration: > 50000 nM
Compound 4 was reported as a limit; the forecaster's own chance of this, stated with the estimate: 50%; middle value at least 1.1-fold (0.04 log units) from the limit.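

Compound 4 puts a 4-acetamidophenyl on the aromatic nitrogen, a group with a hydrogen-bond donor and acceptor, and in this assay compound 4 gives > 50000 nM, which is a limit of the assay and not a number. Against the only compound with a number, the change gives an at least 1.2-fold higher number from compound 1 to compound 4 (0.10 log units; that floor lies within the scatter), and this is only a floor. The steps from compound 2 and from compound 3 to compound 4 cannot be read, and an amide on the aryl ring still leaves the value at the same limit: the limit of > 50000 nM in this assay, at which 3 of the 4 values shown sit.

As far as these compounds go, how far compound 2, compound 3 and compound 4 lie past that limit stays open. Also open, from the compounds shown here alone, is whether a 4-aminophenyl, a 4-carboxyphenyl or an open alkyl chain on this nitrogen would give a measurable value clearly different from that of compound 1.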